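The source may report more compounds than this note shows. Statements on the series, on what has been measured and on what is new or still open speak of the compounds shown alone.

Going by the values given here, compound 2 `N#Cc1cnc(NCc2cnccc2C(F)(F)F)cc1N[C@H]1CC[C@@H](C(N)=O)CC1` holds the lowest number of the two measured so far: in an assay on isolated protein for inhibition of protein kinase C theta type (Homo sapiens), read by TR-FRET, with a stated time of 2 h (on this read-out lower numbers stand for stronger inhibition and higher numbers for weaker inhibition), compound 2 gives 7 nM, while compound 1 `N#Cc1cnc(NCc2cnccc2C(F)(F)F)cc1NC1CCOCC1` gives 900 nM. Among the compounds with values here, the single measured step, a 130-fold lower number from compound 1 to compound 2 (2.11 log units; beyond the scatter), shows that an exchange of the group on the saturated ring can move this assay far. Compound 3 `N#Cc1cnc(NCc2cnccc2C(F)(F)F)cc1N[C@H]1CC[C@@H](n2cncn2)CC1` differs from compound 2 as follows: 1H-1,2,4-triazol-1-yl in place of carbamoyl on a saturated ring carbon. Within the data shown here, no measured step covers this exchange; the carbamoyl group of compound 2 leaves, so a moderate rise in the number is expected, a 3.6-fold higher number from compound 2 to compound 3 (0.55 log units; beyond the scatter). Compound 3 is estimated at 25 nM, with a range from 5 nM to 150 nM.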

Compound 3, half-maximal inhibitory concentration: 100 nM
Estimate against measurement, compound 3: 4.0-fold (0.60 log units) below, within the range that was stated.
By their numbers in this assay, from the lowest: compound 2; then compound 3; then compound 1.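

At this saturated ring carbon, 1H-1,2,4-triazol-1-yl does not replace carbamoyl without loss in this assay: the exchange gives a 14-fold higher number from compound 2 to compound 3 (1.15 log units; beyond the scatter) and counts as large. The printed values still place compound 3 at 100 nM under compound 1 at 900 nM on this read-out. Nothing on hand explains the step. Open, as far as these compounds go, is where a carboxylic acid, a primary amine or an N-methyl carboxamide on this carbon would fall, and so whether the carbamoyl result extends to close relatives of that group.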